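The source may report more compounds than this note shows. Statements on the series, on what has been measured and on what is new or still open speak of the compounds shown alone.

Compound 1 `C=CC(=O)Nc1cc(Nc2ncc(Cl)c(Nc3ccccc3S(=O)(=O)C(C)C)n2)c(OC)cc1N1CCN(S(C)(=O)=O)CC1` in a functional assay on NCI-H3122 cells (Homo sapiens) for inhibition, read by CellTiter-Glo, with a stated time of 72 h (on this read-out lower numbers stand for stronger inhibition of growth and higher numbers for weaker inhibition of growth), gives < 0.3 nM, which is a limit of the assay and not a number (the limit of < 0.3 nM in this assay, at which 1 of the 2 values shown sits). Compound 2 `C=CC(=O)Nc1cc(Nc2ncc(Cl)c(Nc3ccccc3S(=O)(=O)C(C)C)n2)c(OC)cc1N1CCN(C)CC1` gives 33 nM in this assay, the only plain number shown in the series. The step of an at least 110-fold higher number from compound 1 to compound 2 (2.04 log units; beyond the scatter) came with methyl in place of methylsulfonyl on an amine nitrogen in a ring. Compound 3 `C=CC(=O)Nc1cc(Nc2ncc(Cl)c(Nc3ccccc3NC(=O)C(C)(C)C)n2)c(OC)cc1N1CCN(C)CC1` differs from compound 2 in one place: ((tert-butyl)carbonyl)amino in place of isopropylsulfonyl on an aromatic carbon. Among the measured compounds shown here, no measured step touches that position, so the expectation rests on compound 2 alone. Compound 3 is expected to give 120 nM, within 25 nM to 700 nM. The expected step is a 3.6-fold higher number from compound 2 to compound 3 (0.56 log units; beyond the scatter).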

Compound 3, concentration for 50% growth inhibition: 6500 nM
Compound 3: middle estimate off by 54-fold (1.73 log units), on the low side, outside the stated range (above it).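

In this assay, the aromatic carbon ortho to a large group proves sensitive to the change of substituent: ((tert-butyl)carbonyl)amino in place of isopropylsulfonyl gives a 200-fold higher number from compound 2 to compound 3 (2.29 log units; beyond the scatter). A second position in the series therefore carries a large step, alongside the amine nitrogen in the ring. Nothing measured here bears on what lies behind this step.

Open, going by these compounds, is whether methylsulfonyl or acetylamino on this carbon would keep the number of compound 2. Also open, on these data alone, is whether ((tert-butyl)carbonyl)amino costs as much with methylsulfonyl on the ring nitrogen.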